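The source may hold more compounds than are shown below. What is called first, only, known or untested is meant among the compounds shown, and "the series" means these compounds.

Series notes. Compound 3 `CCc1cc(=O)c2ccc(Sc3cccc(Cl)n3)cc2o1` is read in a functional assay on A549 cells (Homo sapiens) for antiproliferative activity, read by sulforhodamine B assay, with a stated time of 72 h; a higher number here means a weaker inhibitor of growth, a lower number a stronger inhibitor of growth. For compound 3 the result is a limit of the assay, > 31400 nM. Compound 2 `CCc1cc(=O)c2ccc(Sc3cccc(Cl)[n+]3[O-])cc2o1` likewise returns only a limit in this assay, namely > 29900 nM. Compound 1 `Cc1cc(=O)oc2cc(SCc3cccc(C#N)c3)ccc12` also returns a limit in this assay, namely > 32500 nM. Compound 3 therefore stands among three values that are all limits, and nothing in the numbers shown separates it from the other two. Compound 4 `CCc1cc(=O)c2ccc(Sc3cccc(Cl)n3)c(C)c2o1` differs from compound 3 in one place: methyl in place of hydrogen on an aromatic carbon. No step between measured compounds is shown, so no size can be read from the data; the expectation is no step beyond the scatter, with the result again most likely a limit. The expected step is an at least 1.0-fold lower number from compound 3 to compound 4 (0.00 log units; that floor lies within the scatter), an estimate only. For compound 4 the estimated value in this assay is 31000 nM, within 10000 nM to 100000 nM.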

Compound 4, concentration for 50% growth inhibition: > 30100 nM
Compound 4 ended at the assay's limit; the forecaster's own chance of this, stated with the estimate: 80%; the middle value does not contradict the limit.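

Among the compounds shown here, compound 3 and compound 4 both return only limits in this assay, so no step between them can be read. The compounds shown leave open whether methyl in place of hydrogen on an aromatic carbon alters growth inhibition.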